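Swapping the amide substituent for 2-hydroxyethyl

The source may report more compounds than this note shows. Statements on the series, on what has been measured and on what is new or still open speak of the compounds shown alone.

Measured compounds in a functional assay on KB cells (Homo sapiens) for antiproliferative activity, read by sulforhodamine B assay, with a stated time of 3 days (a lower number here means a stronger inhibitor of growth, a higher number a weaker inhibitor of growth), are these
- compound 1 `COc1ccc(NC(=O)c2cccc(Nc3ncc(F)c(Nc4ccc(F)cc4)n3)c2)cc1` gives > 10000 nM as a limit
- compound 2 `CN1CCC(C(=O)Nc2cccc(Nc3ncc(F)c(Nc4ccc(F)cc4)n3)c2)CC1` gives 1700 nM
- compound 3 `Cn1ccnc1NC(=O)c1cccc(Nc2ncc(F)c(Nc3ccc(F)cc3)n2)c1` gives 14600 nM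

Compound 3 (14600 nM) holds the highest of the two actual numbers, and the nearest gap lies beyond the scatter (an 8.6-fold higher number from compound 2 to compound 3 (0.93 log units; beyond the scatter)). The value of compound 1 is a limit (the limit of > 10000 nM in this assay, at which 1 of the 3 values shown sits).

Compound 4 `O=C(NCCO)c1cccc(Nc2ncc(F)c(Nc3ccc(F)cc3)n2)c1` has 2-hydroxyethyl in place of 1-methyl-1H-imidazol-2-yl on an amide-type nitrogen. Going by the values given here, the one measured step at that nitrogen cannot be read (a step that the limit leaves unreadable from compound 1 to compound 3). The readable steps (an at least 5.8-fold lower number from compound 1 to compound 2 (0.76 log units; beyond the scatter)) and (an 8.6-fold higher number from compound 2 to compound 3 (0.93 log units; beyond the scatter)) both turn on the ((1-methylpiperidin-4-yl)carbonyl)amino group of compound 2, which compound 4 lacks. Compound 1 and compound 3 (14600 nM) share the carbamoyl link, and compound 4 keeps it. The expected change is therefore small (a 1.6-fold lower number from compound 3 to compound 4 (0.21 log units; within the scatter)) and in this assay need not exceed the scatter. The estimate for compound 4 is 9000 nM within an expected range from 3000 nM to 25000 nM and a reading at the limit is also possible.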

Compound 4, concentration for 50% growth inhibition: 12400 nM
The estimate for compound 4 lay 1.4-fold (0.14 log units) below the measured number; measured number inside the range.
By their numbers in this assay, from the lowest: compound 2; then compounds 4 and 3 (each within the scatter of the next).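

At the amide-type nitrogen, the five-membered aromatic ring of 1-methyl-1H-imidazol-2-yl and the ringless 2-hydroxyethyl chain cannot be told apart in this assay, so this ring is not needed for a number at this level: a 1.2-fold lower number from compound 3 to compound 4 (0.07 log units; within the scatter). Compound 2 stays clearly separate from this ringless carbamoyl compound as well, with a 7.3-fold higher number from compound 2 to compound 4 (0.86 log units; beyond the scatter), as it does from compound 3. Compound 1 stands at a limit, so its steps at this nitrogen cannot be read: the limit of > 10000 nM in this assay, at which 1 of the 4 values shown sits.

Going by these compounds, the step from compound 2 exchanges the link and its substituent together, so it remains open whether 1-methylpiperidin-4-yl on the carbamoyl nitrogen would give the number of compound 2. Also open, on these data alone, is how a tertiary amine at the end of a longer chain, or a carboxylic acid, would read at this nitrogen.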